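Moving the amino group on the aryl ring of a triazole

The compounds below may be only part of what the source reports. "The series", "measured", "known", "first", "only" and "open" are said of these compounds alone.

The series rests on a shared core carrying a trimethoxyphenyl group and a second aryl ring on a five-membered aromatic ring with three nitrogens. Compound 1 `COc1cc(-n2ncnc2-c2ccc(C)cc2)cc(OC)c1OC` in a functional assay on HeLa cells (Homo sapiens) for antiproliferative activity, read by MTT assay, with a stated time of 72 h (on this read-out lower numbers stand for stronger inhibition and higher numbers for weaker inhibition), gives 250 nM. Compound 2 `COc1cc(-c2ncnn2-c2cccc(N)c2)cc(OC)c1OC` differs in the arrangement of the aryl groups around that core and carries a 3-aminophenyl group. In this assay compound 2 gives only a limit, > 10000 nM, so its true potency is not known (the limit of > 10000 nM in this assay, at which 1 of the 2 values shown sits). Compound 3 `COc1cc(-c2ncnn2-c2ccc(N)cc2)cc(OC)c1OC` is the next step: 4-aminophenyl in place of 3-aminophenyl on an aromatic nitrogen. For the measured compounds named here, with the two aryl groups having the same atoms but differently joined, and with compound 2 reaching only a limit, there is no measured step on which to anchor an expectation, so the estimate is loose. The step from compound 2 to compound 3 is expected to be an at least 1.6-fold lower number from compound 2 to compound 3 (0.22 log units; that floor lies within the scatter), with a real chance that compound 3 again returns only a limit. Compound 3 is estimated to give 6000 nM in this assay, with a range from 1500 nM to 25000 nM.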

Compound 3, half-maximal inhibitory concentration: > 10000 nM
Compound 3 gave a limit, no number; the forecaster's own chance of this, stated with the estimate: 45%; at least 1.6-fold (0.22 log units) between middle value and limit.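

In this assay, for the compounds shown here, compound 3 gives only a limit, > 10000 nM, as compound 2 does, so no step between compound 2 and compound 3 can be read: the limit of > 10000 nM in this assay, at which 2 of the 3 values shown sit. The compounds shown leave open how far each of these two lies beyond that limit, and whether 4-aminophenyl and 3-aminophenyl differ in this assay at all.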